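The source may report more compounds than this note shows. Statements on the series, on what has been measured and on what is new or still open speak of the compounds shown alone.

Compound 1, `CC(C)[C@H](NC(=O)COc1cccc2ccccc12)C(=O)N[C@@H](CC(=O)O)C(=O)CSc1nnnn1C`: > 200000 nM
Compound 2, `CC(C)[C@H](NC(=O)COc1cccc2ccccc12)C(=O)N[C@@H](CC(=O)O)C(=O)CSc1nc2ccccc2s1`: > 200000 nM

In a functional assay on Jurkat cells (Homo sapiens) for inhibition (a lower number here means a stronger inhibitor, a higher number a weaker inhibitor), compound 1 gives only a limit, > 200000 nM, not a measured number. Compound 2 likewise gives only a limit, > 200000 nM. The exchange of 1,3-benzothiazol-2-yl for 1-methyl-1H-tetrazol-5-yl on a sulfur therefore cannot be read: a step that the two limits leave unreadable from compound 1 to compound 2. Both values sit at the limit of > 200000 nM in this assay, at which 2 of the 2 values shown sit, so compound 2 stands at that limit and nowhere more precisely.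

Compound 3, `CC(C)[C@H](NC(=O)COc1cccc2ccccc12)C(=O)N[C@@H](CC(=O)O)C(=O)COc1ccnc(C(F)(F)F)n1`, awaits measurement. It differs from compound 2 by (2-(trifluoromethyl)pyrimidin-4-yl)oxy in place of (1,3-benzothiazol-2-yl)sulfanyl on a saturated chain carbon bound to a carbonyl carbon. Among the measured compounds shown here, the only measured step, a step that the two limits leave unreadable from compound 1 to compound 2, alters the group at the same place, yet its size is not readable, so no direction beyond the scatter can be drawn from it. The expected step in this assay is a number no higher from compound 2 to compound 3 (the limit leaves the size open), most probably ending again at a limit rather than a number. Compound 3 is estimated at 200000 nM, within a range from 40000 nM to 600000 nM.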

Compound 3, half-maximal inhibitory concentration: 37000 nM
Compound 3: middle estimate off by 5.4-fold (0.73 log units), on the high side; the measured number lies below the stated range.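

In this assay, the group on the saturated chain carbon bound to a carbonyl carbon now has a readable effect: the (2-(trifluoromethyl)pyrimidin-4-yl)oxy group gives an at least 5.4-fold lower number from compound 2 to compound 3 (0.73 log units; beyond the scatter), and the same group gives an at least 5.4-fold lower number from compound 1 to compound 3 (0.73 log units; beyond the scatter). This shows that a change at this place can move the read-out, which compound 1 and compound 2 could not show on their own. Compound 1 and compound 2 carry only limits, not numbers, so both steps give a minimum size, because the true size stays hidden behind that limit: the limit of > 200000 nM in this assay, at which 2 of the 3 values shown sit.

The change swaps the ring and replaces the linking sulfur with oxygen at once, so the compounds shown cannot separate these two parts or say what the trifluoromethyl contributes. Going by these compounds, it remains open how the same pyrimidine would fare joined through sulfur, or with a methyl group in place of trifluoromethyl.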